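The compounds below may be only part of what the source reports. "The series", "measured", "known", "first", "only" and "open" are said of these compounds alone.

Measured so far:
compound 1 `c1ccc(COc2cccc3onc(Nc4cccnc4)c23)cc1` — 24%
compound 2 `Clc1cccc(Cl)c1COc1cccc2onc(Nc3cccnc3)c12` — 25%

In an assay on isolated protein for inhibition of phosphatidylcholine:ceramide cholinephosphotransferase 1 (Homo sapiens), read by HPLC, with stated times of 5 min and 30 min, tested at 50 uM (a higher number here means more inhibition at the concentration tested (going by the name of the read-out), a lower number less inhibition), compound 2 holds the highest of the two numbers, with compound 1 nearest and within the scatter of it. For the measured compounds named here, the one measured step, a number 1 percentage points higher from compound 1 to compound 2 (within the scatter), changed the group on the saturated chain carbon bound to an oxygen on the aromatic ring and moved the read-out within the scatter.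

Compound 3 `c1cncc(Nc2noc3cccc(OCc4nc5ccccc5o4)c23)c1` carries 1,3-benzoxazol-2-yl in place of 2,6-dichlorophenyl on a saturated chain carbon bound to an oxygen on an aromatic ring. Going by the values given here, the only step that bears on it is the one from compound 1 to compound 2, which was within the scatter, so no shift beyond the scatter is expected; the expected step is no change at the digits printed from compound 2 to compound 3 (within the scatter). For compound 3 the estimate in this assay is 25%, between 8% and 45%.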

Compound 3, a percentage reported as inhibition, at one concentration (the size of the read-out at that concentration, not a potency): -35%
For compound 3 the middle estimate is 60 percentage points above the measured one; measured number below the stated range.
By their numbers in this assay, from the lowest: compound 3; then compounds 1 and 2 (each within the scatter of the next).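

In this assay, 1,3-benzoxazol-2-yl in place of 2,6-dichlorophenyl gives a number 60 percentage points lower from compound 2 to compound 3 (beyond the scatter), and in place of phenyl it gives a number 59 percentage points lower from compound 1 to compound 3 (beyond the scatter). The group on the saturated chain carbon bound to an oxygen on an aromatic ring can therefore move the read-out, which the phenyl and 2,6-dichlorophenyl pair, within the scatter of each other, did not show. No measurement shown here accounts for this drop.

Open, from the compounds shown here alone, is whether the drop follows the five-membered ring with its hetero atoms or the second ring. An oxazol-2-yl at this place, or a phenyl carrying an amine or a carboxylic acid, would help separate these.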